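Swapping the Distal Aryl Group in a Receptor Agonist Series

The source may report more compounds than this note shows. Statements on the series, on what has been measured and on what is new or still open speak of the compounds shown alone.

Compound 1, `CC(C)C[C@H](N)CN(C(=O)[C@@H]1C[C@H]1c1ccccc1)c1ccc(-c2ccncc2)cc1`: 13000 nM
Compound 2, `CC(C)C[C@H](N)CN(C(=O)[C@@H]1C[C@H]1c1ccccc1)c1ccc(-c2ccoc2)cc1`: 2000 nM
Compound 3, `Cc1cccc(-c2ccc(N(C[C@@H](N)CC(C)C)C(=O)[C@@H]3C[C@H]3c3ccccc3)cc2)c1`: 1200 nM

All three were tested in a functional assay for agonist activity at G protein-coupled receptor 88 (Homo sapiens), read by HTRF and cAMP accumulation; on this read-out lower numbers stand for an effect already at smaller amounts and higher numbers for an effect only at larger amounts of compound. Compound 3 gives the lowest of the three numbers: the step of an 11-fold lower number from compound 1 to compound 3 (1.03 log units; beyond the scatter) lies beyond the scatter, whereas the step of a 1.7-fold lower number from compound 2 to compound 3 (0.22 log units; within the scatter) lies within it, so compound 3 and compound 2 cannot be separated. Compound 4, `COc1ccc(-c2ccc(N(C[C@@H](N)CC(C)C)C(=O)[C@@H]3C[C@H]3c3ccccc3)cc2)cc1`, differs from compound 3 in one place: 4-methoxyphenyl in place of 3-methylphenyl on an aromatic carbon. Among the compounds with values here, no measured step exchanges one six-membered carbon ring for another; the only steps known start from a pyridin-4-yl, such as a 6.5-fold lower number from compound 1 to compound 2 (0.81 log units; beyond the scatter). Because the steps of an 11-fold lower number from compound 1 to compound 3 (1.03 log units; beyond the scatter) and a 1.7-fold lower number from compound 2 to compound 3 (0.22 log units; within the scatter) show that aryl groups without a ring nitrogen sit close together, the expected step is small, a 1.3-fold higher number from compound 3 to compound 4 (0.10 log units; within the scatter). Compound 4 is therefore estimated at 1500 nM, within 500 nM to 4500 nM.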

Compound 4, half-maximal effective concentration: 330 nM
Compound 4: middle estimate off by 4.5-fold (0.66 log units), on the high side, outside the stated range (below it).
By their numbers in this assay, from the lowest: compound 4; then compounds 3 and 2 (each within the scatter of the next); then compound 1.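

Even among aryl rings of carbon only, the group at this position matters: a 3.6-fold lower number from compound 3 to compound 4 (0.56 log units; beyond the scatter) lies beyond the scatter, so 4-methoxyphenyl and 3-methylphenyl are not interchangeable. Compound 4 also stands clear of the furan-3-yl compound, with a 6.1-fold lower number from compound 2 to compound 4 (0.78 log units; beyond the scatter) as the step, and of the pyridin-4-yl compound, with a 39-fold lower number from compound 1 to compound 4 (1.60 log units; beyond the scatter) as the step, giving the lowest number of the four. Nothing available explains these steps.

Still open, as far as these compounds go, is whether the gain follows the oxygen or the ring position, since 3-methylphenyl and 4-methoxyphenyl differ in both. A 4-methylphenyl or 4-aminophenyl group would help separate the two.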